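Swapping one side chain for another

The source may hold more compounds than are shown below. What is called first, only, known or untested is meant among the compounds shown, and "the series" means these compounds.

Measured so far in a physicochemical assay for solubility, in phosphate buffer, at pH 7.2; on this read-out lower numbers stand for lower solubility and higher numbers for higher solubility:
- compound 1 `COc1cc(C2CN(C(=O)c3cc(OCCO)ccn3)C2)ccc1OCc1ccc(C2CC2)cc1`: 800 nM
- compound 2 `COc1cc(C2CN(C(=O)c3cc(OCCCC(=O)O)ccn3)C2)ccc1OCc1ccc(C2CC2)cc1`: 1100 nM

With only compound 1 for comparison, compound 2 at 1100 nM cannot be separated from it, as the two values lie within the scatter of each other. Compound 3 `COc1cc(C2CN(C(=O)c3cc(COC[C@H](O)CO)ccn3)C2)ccc1OCc1ccc(C2CC2)cc1` carries (2,3-dihydroxypropoxy)methyl in place of 3-carboxypropoxy on an aromatic carbon. For the measured compounds named here, one measured step bears on this change, since it also alters this side chain: a 1.4-fold higher number from compound 1 to compound 2 (0.14 log units; within the scatter). Going by the values given here, that step is small, but it is the only guide, and the group in compound 3 has not been measured in any other compound. No step beyond the scatter is therefore expected in this assay, and no direction can be favoured. The expected change is a 1.2-fold lower number from compound 2 to compound 3 (0.09 log units; within the scatter). For compound 3 the estimated value is 900 nM, with an expected range of 350 nM to 2500 nM.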

Compound 3, solubility: 6700 nM
Estimate against measurement, compound 3: 7.4-fold (0.87 log units) below, and the stated range ends below it.
By their numbers in this assay, from the lowest: compounds 1 and 2 (each within the scatter of the next); then compound 3.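

In this assay, the side chain opposite the ring nitrogen can shift the number beyond the scatter, which the step between compound 1 and compound 2 did not show. Putting (2,3-dihydroxypropoxy)methyl in place of 3-carboxypropoxy gives a 6.1-fold higher number from compound 2 to compound 3 (0.78 log units; beyond the scatter) even though the two groups have the same number of heavy atoms, and putting it in place of 2-hydroxyethoxy gives an 8.4-fold higher number from compound 1 to compound 3 (0.92 log units; beyond the scatter) as well. No measurement shown here accounts for this rise.

The compounds shown leave open which part of (2,3-dihydroxypropoxy)methyl matters: the pair of hydroxy groups, the carbon that joins the chain to the ring, or the defined stereocentre. Going by these compounds, it is also open whether a different chain at this position, such as one ending in an amine or a longer chain carrying more hydroxy groups, would give a similar number.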